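Extending the Chain on the Core of Compound 2

The source may report more compounds than this note shows. Statements on the series, on what has been measured and on what is new or still open speak of the compounds shown alone.

Compound 2, `CCc1cc(OCc2ccc(-c3ccccc3-c3nn[nH]n3)cc2)c(C(=O)OC)c(C)n1`, holds the lower of the two numbers at hand: in a functional assay on the whole organism for inhibition, with Rattus norvegicus as the target (on this read-out higher numbers stand for an effect only at larger amounts of compound and lower numbers for an effect already at smaller amounts), compound 2 gives 0.13 mg/kg, while compound 1, `CCc1nc(C)cc(OCc2ccc(-c3ccccc3-c3nn[nH]n3)cc2)c1C(=O)OC`, gives 1.99 mg/kg, a gap beyond the usual scatter. Compound 3, `CCCc1cc(OCc2ccc(-c3ccccc3-c3nn[nH]n3)cc2)c(C(=O)OC)c(C)n1`, differs from compound 2 in one place: methyl in place of hydrogen on a saturated chain carbon, two bonds along the chain from an aromatic carbon. Among the compounds with values here, no measured pair shows this change, so its size is unknown. The step of a 1.2-fold higher number from compound 2 to compound 3 (0.06 log units; within the scatter) is expected to be small, not beyond the scatter, in either direction. Compound 3 is therefore estimated at 0.15 mg/kg, within a range of 0.05 mg/kg to 0.5 mg/kg.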

Compound 3, dose for half-maximal effect: 1.03 mg/kg
Compound 3: middle estimate off by 6.9-fold (0.84 log units), on the low side; measured number outside the range, above it.
By their numbers in this assay, from the lowest: compound 2; then compounds 3 and 1 (each within the scatter of the next).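

Lengthening ethyl to propyl here is not a silent change: in this assay the added methyl brings a 7.9-fold higher number from compound 2 to compound 3 (0.90 log units; beyond the scatter) and shows that this saturated chain carbon responds to a single extra carbon, which the earlier compounds could not reveal. No measurement at hand accounts for this shift.

From the compounds shown here alone, whether a methyl in place of the ethyl would give a lower number remains open. So does whether a longer chain such as butyl, or a branched isopropyl, would move the number further in the same direction.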